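This account rests on a few compounds, and the source may have more. Where it says the series, first, only, none or still open, it means among the compounds named here.

Working notes on the series. In a functional assay on P388D1 cells (Homo sapiens) for antiproliferative activity, read by sulforhodamine B assay, with a stated time of 48 h (a higher number here means a weaker inhibitor, a lower number a stronger inhibitor), compound 1 (`Cc1cccc(NS(=O)(=O)c2ccc(N3CCNC3=O)cc2)c1`) gives 250 nM, compound 3 (`O=C1NCCN1c1ccc(S(=O)(=O)Nc2cccc(Br)c2)cc1`) gives 90 nM and compound 2 (`COc1cc(NS(=O)(=O)c2ccc(N3CCNC3=O)cc2)cc(OC)c1OC`) gives 38 nM. Compound 3 therefore holds the middle of the three numbers, with a value lower than that of compound 1 and higher than that of compound 2.

The next compound is compound 4 (`Cc1ccc(C)c(NS(=O)(=O)c2ccc(N3CCNC3=O)cc2)c1`), which has 2,5-dimethylphenyl in place of 3-bromophenyl on a sulfonamide nitrogen.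

Among the compounds with values here, one measured step bears on this change: a 2.8-fold lower number from compound 1 to compound 3 (0.44 log units; beyond the scatter). In that modest step, bromo takes the place of methyl on an aromatic carbon. The change to compound 4 runs the other way, from bromo back to methyl, so a modest step to a higher number is expected in this assay, of about the same size. Within the data shown here, no measured compound carries the 2,5-dimethylphenyl group, so the effect of the second methyl remains untested and the range is kept wide.

The expected step is a 2.2-fold higher number from compound 3 to compound 4 (0.35 log units; beyond the scatter). For compound 4 the estimated value is 200 nM, with an expected range of 70 nM to 600 nM.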

Compound 4, half-maximal inhibitory concentration: 79 nM
Compound 4: the middle estimate sits 2.5-fold (0.40 log units) above what was measured, and the stated range covers the measured number.
By their numbers in this assay, from the lowest: compound 2; then compounds 4 and 3 (each within the scatter of the next); then compound 1.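

In this assay the exchange of 3-bromophenyl for 2,5-dimethylphenyl on a sulfonamide nitrogen gives a 1.1-fold lower number from compound 3 to compound 4 (0.06 log units; within the scatter) and so leaves the number unmoved within the scatter: at this position, a ring carrying only methyl groups can stand level with the bromo ring. The other reading of the same compound gives a 3.2-fold lower number from compound 1 to compound 4 (0.50 log units; beyond the scatter) for methyl in place of hydrogen on an aromatic carbon, so an added methyl on this ring can shift the number by about as much as the earlier exchange of methyl for bromo. No measurement at hand accounts for either step.

Still open is whether this added methyl would have the same effect on other rings, since compound 4 is the only case of this change in the compounds shown. Also open, as far as these compounds go, is how the number responds to groups of another kind on this ring, such as chloro, an amine or a carboxylic acid, or to a longer chain in place of methyl.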